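Removing the side chain from a sulfur-linked core

A few compounds are considered here, and "the series" means these few. Any claim that something is new, unique, unknown or untested is made for them only; others in the source may bear on it.

Compound 1 `CC(C)CCSc1nncc2cncn12`: in a functional assay for inhibition, with Homo sapiens as the target (a lower number here means a stronger inhibitor, a higher number a weaker inhibitor), compound 1 gives 9000 nM.
Compound 2 `CCOC(=O)CSc1nncc2cncn12`: in this assay compound 2 reaches only the limit > 48000 nM.
Compound 3 `COc1ccc(-c2ncc3cnnc(O)n23)cc1`: in this assay compound 3 likewise reaches only the limit > 48000 nM.

Going by the values given here, compound 1 thus holds the only measured number, while compound 2 and compound 3 stand at a limit, as the limit of > 48000 nM in this assay, at which 2 of the 3 values shown sit, records. Compound 4 `Sc1nncc2cncn12` differs from compound 1 in one place: hydrogen in place of isopentyl on a sulfur. Among the compounds with values here, the one measured step, an at least 5.3-fold higher number from compound 1 to compound 2 (0.72 log units; beyond the scatter), shows that swapping the chain on that sulfur for a different group weakened inhibition. Taking the chain away entirely is a different change, so that step is only a loose guide. Still, a weaker inhibitor is expected, with the step of a 4.4-fold higher number from compound 1 to compound 4 (0.65 log units; beyond the scatter). Compound 4 is therefore estimated at 40000 nM, within 10000 nM to 150000 nM, with a real chance that only a limit is reported.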

Compound 4, half-maximal inhibitory concentration: > 48000 nM
Compound 4: a limit, no number (the forecaster's own chance of this, stated with the estimate: 55%); at least 1.2-fold (0.07 log units) between middle value and limit.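

With hydrogen on the sulfur, compound 4 gives only a limit in this assay, not a number. The step is therefore a minimum: an at least 5.3-fold higher number from compound 1 to compound 4 (0.72 log units; beyond the scatter). Compound 2 swapped the chain for another group, whereas this change removes it altogether, and inhibition reaches a measured number only with the isopentyl chain in place.

Going by these compounds, how large the true loss is stays open, since the values crowd at one point: the limit of > 48000 nM in this assay, at which 3 of the 4 values shown sit. Also open is how a longer chain, or a chain ending in an amine, would compare on that sulfur.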